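Dropping a Chloro Group from a Thiourea Cytotoxicity Lead

This account rests on a few compounds, and the source may have more. Where it says the series, first, only, none or still open, it means among the compounds named here.

Measured so far:
compound 1, `Fc1ccc(NC(=S)Nc2nc3ccc(F)cc3s2)cc1`, 34600 nM
compound 2, `S=C(Nc1ccccc1)Nc1nc2c(Cl)cccc2s1`, 31800 nM

Both compounds were tested in a functional assay on THP-1 cells (Homo sapiens) for cytotoxicity, read by MTT assay, with a stated time of 48 h; on this read-out lower numbers stand for stronger inhibition and higher numbers for weaker inhibition. On these two numbers compound 2 gives the lowest value, with compound 1 standing nearest; the gap between them lies within the scatter of repeated measurements, so neither can be called the more active.

The next compound, compound 3, `S=C(Nc1ccccc1)Nc1nc2ccccc2s1`, is not yet measured. It differs from compound 2 in one place: hydrogen in place of chloro on an aromatic carbon. The chloro group leaves, a hydrogen atom enters, on an aromatic carbon of a six-membered aromatic ring of carbon only, part of a fused system of two rings.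

Within the data shown here, no measured pair shows what removing a chloro does here, so the expectation rests on compound 2 alone. A small step is expected in this assay, toward a somewhat higher number, though a result within the scatter would not be surprising. For compound 3 the estimated value is 40000 nM, with a range from 15000 nM to 110000 nM; this estimate means a step of a 1.3-fold higher number from compound 2 to compound 3 (0.10 log units; within the scatter).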

Compound 3, half-maximal inhibitory concentration: 36500 nM
For compound 3 the middle estimate is 1.1-fold (0.04 log units) above the measured one, and the stated range covers the measured number.
By their numbers in this assay, from the lowest: compounds 2, 1 and 3 (each within the scatter of the next).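

In this assay replacing the chloro group with hydrogen on this aromatic carbon gives a 1.1-fold higher number from compound 2 to compound 3 (0.06 log units; within the scatter), so the two compounds cannot be told apart. At this position, then, the chloro group is not needed to keep the cytotoxicity seen with compound 2, and hydrogen serves equally well on this read-out. No separate measurement helps explain why this swap leaves the number so little changed.

It remains open whether other groups at this position, such as an amine or a methoxy group, would leave the value just as unmoved, since the compounds shown carry only chloro or hydrogen there. Compound 1 also differs from compound 3 in more than one place, so the effect of each of its fluoro groups alone cannot be read.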